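A few compounds are considered here, and "the series" means these few. Any claim that something is new, unique, unknown or untested is made for them only; others in the source may bear on it.

Measured compounds in a functional assay on MDA-MB-435S cells (Homo sapiens) for antiproliferative activity, read by MTT assay, with a stated time of 72 h; on this read-out lower numbers stand for stronger inhibition and higher numbers for weaker inhibition:
compound 1, `Cc1ccc2c(=O)c(CSC(=S)N(C(C)C)C(C)C)coc2c1`: 240 nM
compound 2, `O=c1c(CSC(=S)N2CCOCC2)coc2ccccc12`: 3900 nM
compound 3, `Cc1ccc2c(=O)c(CSC(=S)N3CCOCC3)coc2c1`: 5500 nM

The cores of compound 2 and compound 3 differ by hydrogen in place of methyl on an aromatic carbon; the step is a 1.4-fold higher number from compound 2 to compound 3 (0.15 log units; within the scatter). The change from compound 3 to compound 1 is diisopropylamino in place of morpholin-4-yl on a thiocarbonyl carbon, and it gave a 23-fold lower number from compound 3 to compound 1 (1.36 log units; beyond the scatter). The unmeasured compound 4, `CC(C)N(C(=S)SCc1coc2ccccc2c1=O)C(C)C`, carries the same change relative to compound 2, (diisopropylamino in place of morpholin-4-yl on a thiocarbonyl carbon), at a place described in identical words, so it is the same change, here on the core of compound 2. As the two cores sit within the scatter of each other in this assay, a step of similar size is expected: a 20-fold lower number from compound 2 to compound 4 (1.29 log units; beyond the scatter), resting on compound 1 with 240 nM and the step of a 23-fold lower number from compound 3 to compound 1 (1.36 log units; beyond the scatter). Compound 4 is thus estimated at 200 nM, between 80 nM and 500 nM.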

Compound 4, half-maximal inhibitory concentration: 7900 nM
Beside the measured number, compound 4's estimate is 40-fold (1.60 log units) below it; measured number above the stated range.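

In this assay, diisopropylamino in place of morpholin-4-yl on a thiocarbonyl carbon does not carry over from one core to the other: the same change on two cores in this assay, a 23-fold lower number (1.36 log units; beyond the scatter) from compound 3 to compound 1 and a 2.0-fold higher number (0.31 log units; beyond the scatter) from compound 2 to compound 4, 46-fold (1.67 log units) apart, beyond the scatter of two such steps

Likewise, hydrogen in place of methyl on an aromatic carbon gives a 33-fold higher number from compound 1 to compound 4 (1.52 log units; beyond the scatter), a far larger step than the one seen with morpholin-4-yl: the same change on two cores in this assay, a 1.4-fold higher number (0.15 log units; within the scatter) from compound 2 to compound 3 and a 33-fold lower number (1.52 log units; beyond the scatter) from compound 4 to compound 1, 46-fold (1.67 log units) apart, beyond the scatter of two such steps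

Of these four compounds, only compound 1, with methyl and diisopropylamino together, gives 240 nM, so the two changes do not act independently here, though one such set shows neither why nor how generally this holds; on the core of compound 2 the change gives only a 2.0-fold higher number from compound 2 to compound 4 (0.31 log units; beyond the scatter).

On these data alone, it remains open whether the same dependence appears with other amines on the thiocarbonyl carbon, such as diethylamino or piperidin-1-yl. Also open, as far as these compounds go, is the outcome with a group other than methyl on the aromatic carbon, such as chloro or methoxy.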